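Diethoxymethyl for Carboxyethyl: Three Limits and One Expectation

This account rests on a few compounds, and the source may have more. Where it says the series, first, only, none or still open, it means among the compounds named here.

Compound 1 `CC(C)=CCC[C@H](C)c1ccc(C)c2c1OCN(CCCCC(=O)O)C2`: in an ADME assay on MDA-MB-231 cells (Homo sapiens) for inhibition, read by MTT assay, with a stated time of 24 h (on this read-out lower numbers stand for stronger inhibition and higher numbers for weaker inhibition), compound 1 gives > 20000 nM.
Compound 2 `CC(C)=CCC[C@H](C)c1ccc(C)c(CNCCCCC(=O)O)c1O`: in this assay compound 2 gives > 20000 nM.
Compound 3 `CCOC(CCN1COc2c([C@@H](C)CCC=C(C)C)ccc(C)c2C1)OCC`: in this assay compound 3 gives > 20000 nM.

Each of these three values is a limit of this assay rather than a number. Compound 3 differs from compound 1 by diethoxymethyl in place of 2-carboxyethyl on a saturated chain carbon, two bonds along the chain from an amine nitrogen in a ring. The step from compound 1 to compound 3 is a step that the two limits leave unreadable from compound 1 to compound 3. Compound 4 `CCOC(CCNCc1c(C)ccc([C@@H](C)CCC=C(C)C)c1O)OCC` has not yet been measured; it differs from compound 2 by diethoxymethyl in place of 2-carboxyethyl on a saturated chain carbon, two bonds along the chain from an amine nitrogen. The two changes are the same kind of change, but the place differs: in compound 1 the amine nitrogen is in a ring, in compound 2 it is not. The difference between the two cores is not broken down here.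

For compound 4 the step from compound 2 is expected to be a step that the limit leaves unreadable from compound 2 to compound 4. This rests on (the limit of > 20000 nM in this assay, at which 3 of the 3 values shown sit). Compound 4 is therefore expected to give 40000 nM, between 15000 nM and 150000 nM.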

Compound 4, half-maximal inhibitory concentration: > 20000 nM
Compound 4 gave a limit, no number (the forecaster's own chance of this, stated with the estimate: 85%); the middle value lies beyond the limit too.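

Among the compounds shown here, compound 2 and compound 4 both give only a limit, so no step between them can be read. The compounds shown leave open whether diethoxymethyl in place of 2-carboxyethyl changes inhibition at all in this assay.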